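Swapping Fluoro for Methyl on a Sulfone Aryl Ring

The source may hold more compounds than are shown below. What is called first, only, known or untested is meant among the compounds shown, and "the series" means these compounds.

Of the compounds shown here, three have been measured in an assay for inhibition of Nicotinamide phosphoribosyltransferase (Homo sapiens), read by mass spectrometry, with stated times of 15 min and 30 min; a lower number here means a stronger inhibitor, a higher number a weaker inhibitor. Compound 1 `O=C(NCc1ccc(S(=O)(=O)c2cccc(F)c2)cc1)c1cc2cnccc2[nH]1` gives 5 nM in this assay. Compound 3 `O=C(NCc1ccc(S(=O)(=O)c2ccccc2)cc1)c1cnc2nccn2c1` gives 2 nM in this assay, a lower number than compound 1 by a margin beyond the usual scatter, so of the two plain numbers shown, compound 1 stands at the higher one. Compound 2 `CC(NC(=O)c1cc2cnccc2[nH]1)c1ccc(S(=O)(=O)N2CCCCC2)cc1` reaches only a limit of this assay, > 10000 nM, which is the limit of > 10000 nM in this assay, at which 1 of the 3 values shown sits.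

Compound 4 `Cc1cccc(S(=O)(=O)c2ccc(CNC(=O)c3cc4cnccc4[nH]3)cc2)c1` has not yet been measured in this assay. It differs from compound 1 in one place: methyl in place of fluoro on an aromatic carbon. Within the data shown here, no pair of measured compounds shows this same swap, so there is no measured step to lean on, and compound 1 is the only direct point of comparison. With one heavy atom exchanged for one other heavy atom and the rest of the molecule unchanged, the expected step from compound 1 to compound 4 is a 1.2-fold higher number from compound 1 to compound 4 (0.08 log units; within the scatter), which is within the scatter and without a clear direction. Compound 4 is therefore estimated at 6 nM in this assay, with an expected range from 2 nM to 20 nM.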

Compound 4, half-maximal inhibitory concentration: 8 nM
Compound 4: middle estimate off by 1.3-fold (0.12 log units), on the low side, within the range that was stated.
By their numbers in this assay, from the lowest: compound 3; then compounds 1 and 4 (each within the scatter of the next). At a limit, above all of these: compound 2.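

Exchanging fluoro for methyl at this position, the change from 3-fluorophenyl to 3-methylphenyl, gives a 1.6-fold higher number from compound 1 to compound 4 (0.20 log units; within the scatter) in this assay and leaves the two compounds indistinguishable. Among these compounds, this is the first measured pair that isolates a single change on this ring, as the earlier compounds each differed from one another in more than one place. Within this one pair, a fluoro and a methyl on this aromatic carbon, each a single heavy atom with no net charge, read alike, and nothing in the information at hand bears on why.

From the compounds shown here alone, whether a group of a different kind at this position, such as an amine, a carboxylic acid or a longer chain, would also read alike remains open. Also open is how the core of compound 1 reads with no substituent on this ring at all: the one plain phenyl sulfone shown, compound 3, carries a different core, and that comparison therefore says nothing about this position.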